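Swapping the Ring on the Amide Nitrogen of Compound 2

The source may hold more compounds than are shown below. What is called first, only, known or untested is meant among the compounds shown, and "the series" means these compounds.

Three compounds have been measured in a functional assay on HOS-TE85 cells (Homo sapiens) for inhibition, read by CCK-8 assay, with a stated time of 72 h; a lower number here means a stronger inhibitor, a higher number a weaker inhibitor:

compound 1, `COc1ccccc1N1C(=O)CSC1c1cccc(C(=O)NCCCCc2ccc(Cl)cc2)c1`: 78.6 nM
compound 2, `CC(C)(C)c1conc1N1C(=O)CSC1c1cccc(C(=O)NCCCCc2ccccc2)c1`: > 1000 nM
compound 3, `CC1SC(c2cccc(C(=O)NCCCCc3ccc(Cl)cc3)c2)N(c2cccc(C3CC3)c2)C1=O`: 932 nM.

The reading of compound 2 is a limit of the assay, not a number: > 1000 nM. Among the compounds with values here, it is the one value that sits at the limit of > 1000 nM in this assay, at which 1 of the 3 values shown sits. Compound 1 gives 78.6 nM, compound 3 gives 932 nM; neither differs from compound 2 in one place only, so these values stand on their own.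

Compound 4, `COc1cc(F)ccc1N1C(=O)CSC1c1cccc(C(=O)NCCCCc2ccccc2)c1`, differs from compound 2 by a group of 9 heavy atoms (7 carbon, 1 oxygen, 1 fluorine; one six-membered aromatic ring of carbon only) in place of a group of 9 heavy atoms (7 carbon, 1 nitrogen, 1 oxygen; one five-membered aromatic ring with 2 hetero atoms), on an amide-type nitrogen in a ring. Within the data shown here, the group that enters resembles the one carried by compound 1 at the same place. A step toward stronger inhibition is therefore expected, an at least 4.0-fold lower number from compound 2 to compound 4 (0.60 log units; beyond the scatter). Compound 4 is estimated at 250 nM, between 60 nM and 1000 nM.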

Compound 4, half-maximal inhibitory concentration: 71.1 nM
Compound 4: the middle estimate sits 3.5-fold (0.55 log units) above what was measured; the range from low to high includes it.
By their numbers in this assay, from the lowest: compounds 4 and 1 (each within the scatter of the next); then compound 3. At a limit, above all of these: compound 2.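

In this assay, within the data shown here, placing 4-fluoro-2-methoxyphenyl on the amide-type nitrogen in a ring gives an at least 14-fold lower number from compound 2 to compound 4 (1.14 log units; beyond the scatter), the first step here between compounds that differ in one place, and it shows that the group at this position can change the read-out well beyond the scatter. The group that leaves and the group that enters have the same count of heavy atoms, so that count alone does not separate them. Compound 2 stands at a limit, so the size of this step is only a bound: the limit of > 1000 nM in this assay, at which 1 of the 4 values shown sits.

The compounds shown leave open how much the fluorine and the methoxy group each contribute. They also leave open how a plain phenyl, a pyridine ring or an aminophenyl group would read at this position.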